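This account rests on a few compounds, and the source may have more. Where it says the series, first, only, none or still open, it means among the compounds named here.

Measured in a functional assay on SW480 cells (Homo sapiens) for antiproliferative activity, read by MTT assay, with a stated time of 48 h; a lower number here means a stronger inhibitor, a higher number a weaker inhibitor:
- compound 1 `CCCCCC(CCO)n1cnc2c(Cl)ncnc21`: > 50000 nM (a limit)
- compound 2 `CCCCCC(CCO)n1cnc2c(OC)ncnc21`: > 50000 nM (a limit)
- compound 3 `CCCCCC(CCO)n1cnc2c(N(C)C)ncnc21`: > 50000 nM (a limit)

In this assay compound 2 gives > 50000 nM, which is a limit and not a number. Within the data shown here, the series so far stands at the limit of > 50000 nM in this assay, at which 3 of the 3 values shown sit, so compound 2 has no numeric value to be ranked against.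

Compound 4 `CCCCCCCCCC(CCO)n1cnc2c(OC)ncnc21` differs from compound 2 in the chain alone: butyl in place of hydrogen on a saturated chain carbon, six bonds along the chain from an aromatic nitrogen.

The measured steps are a step that the two limits leave unreadable from compound 1 to compound 2, a step that the two limits leave unreadable from compound 1 to compound 3 and a step that the two limits leave unreadable from compound 2 to compound 3. All three change the group on an aromatic carbon, and none touches the chain. Among the measured compounds shown here, no measured step therefore gives a size for this change. Only a modest move towards stronger inhibition in this assay is expected, with a real chance that compound 4 also ends at a limit.

The expected step is an at least 1.6-fold lower number from compound 2 to compound 4 (0.22 log units; that floor lies within the scatter). For compound 4 the estimated value is 30000 nM, with an expected range of 8000 nM to 60000 nM.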

Compound 4, half-maximal inhibitory concentration: 3250 nM
Compound 4: the middle estimate sits 9.2-fold (0.97 log units) above what was measured, outside the stated range (below it).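

In this assay, among these compounds, the chain is the first place where a change can be read: butyl in place of hydrogen on a saturated chain carbon, six bonds along the chain from an aromatic nitrogen, gives an at least 15-fold lower number from compound 2 to compound 4 (1.18 log units; beyond the scatter). The steps among compound 1, compound 2 and compound 3, all changes of the group on an aromatic carbon, cannot be read, so this position is the only one shown to move the series in this assay. Compound 2 is held at a limit, so the step is a floor, and compound 4 alone has a numeric value: the limit of > 50000 nM in this assay, at which 3 of the 4 values shown sit.

As far as these compounds go, whether a longer chain than that of compound 4 goes further, or a shorter one already gives a numeric value, stays open. Also open, from the compounds shown here alone, is whether chloro, dimethylamino or an amine on the aromatic carbon would behave differently from methoxy when paired with the longer chain.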